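The compounds below may be only part of what the source reports. "The series", "measured", "known", "first", "only" and "open" are said of these compounds alone.

In a functional assay (trachea) with Rattus norvegicus as the target (on this read-out higher numbers stand for higher potency (the scale is a negative logarithm) and lower numbers for lower potency), the three measured compounds read as follows:
compound 1 `CC1(C)C=C(n2ccccc2=O)c2cc(C(=O)c3cccs3)ccc2O1` gives 5.84;
compound 2 `CC1(C)C=C(n2ccccc2=O)c2cc(C(=O)c3ccc(O)cc3)ccc2O1` gives 5.87;
compound 3 `CC1(C)C=C(n2ccccc2=O)c2cc(C(=O)c3ccccc3F)ccc2O1` gives 6.34.

Compound 3 stands highest of the three. Its nearest neighbour is compound 2, and the gap a number 0.47 log units higher from compound 2 to compound 3 (beyond the scatter) lies beyond the scatter; the gap to compound 1, a number 0.50 log units higher from compound 1 to compound 3 (beyond the scatter), is beyond the scatter as well. Compound 1 and compound 2 are themselves separated only by a number 0.03 log units higher from compound 1 to compound 2 (within the scatter), which is within the scatter.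

Compound 4 `CC1(C)C=C(n2ccccc2=O)c2cc(C=O)ccc2O1` is the next compound to be measured. The change from compound 3 is hydrogen in place of 2-fluorophenyl on a carbonyl carbon. Among the measured compounds shown here, the measured steps all exchange one ring for another on that carbonyl carbon; none removes the ring altogether, so no step bears directly on this change. They do show that the group on the carbonyl carbon moves the read-out by modest amounts. Removing it entirely is a larger structural change than any of those exchanges, and a fall is expected, but its size is uncertain. For compound 4 the estimate in this assay is 5.3, with a range from 4.6 to 6. That estimate corresponds to an expected step of a number 1.04 log units lower from compound 3 to compound 4 (beyond the scatter).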

Compound 4, logarithm of the reciprocal of the active concentration, log(1/C): 6.14
Estimate against measurement, compound 4: 0.84 log units below, and the stated range ends below it.
By their numbers in this assay, from the lowest: compounds 1, 2, 4 and 3 (each within the scatter of the next, the first and the last beyond it).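

In this assay, taking the ring off the carbonyl carbon altogether proves no more consequential than exchanging one ring for another: the steps read a number 0.20 log units lower from compound 3 to compound 4 (within the scatter) and a number 0.27 log units higher from compound 2 to compound 4 (within the scatter) and a number 0.30 log units higher from compound 1 to compound 4 (within the scatter), so the formyl compound 4 cannot be told apart from any of the three ring-bearing compounds. It therefore sits within the scatter of both compound 1 and compound 3, even though those two are separated by a number 0.50 log units higher from compound 1 to compound 3 (beyond the scatter), and the ring compounds as a set show no clear gain or loss against hydrogen at this place, with 2-fluorophenyl, 4-hydroxyphenyl and thiophen-2-yl all falling close to it. Nothing available explains why the read-out tolerates the loss of the ring.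

As far as these compounds go, what remains open is whether an amine or a hydroxyl on the carbonyl carbon, giving an amide or a carboxylic acid, or a longer alkyl chain there would stay in this same narrow band. From the compounds shown here alone, it is also open whether the exchange of 2-fluorophenyl for hydrogen would read the same with a different group elsewhere on the shared core.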